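Solubility notes on the dipropylaminoethyl compounds

This account rests on a few compounds, and the source may have more. Where it says the series, first, only, none or still open, it means among the compounds named here.

Compound 1 `[O-][n+]1nc(NCCN2CCCCC2)[n+]([O-])c2ccccc21` gives > 49000000 nM in a physicochemical assay for solubility, in the presence of a further agent that is not named here; a higher number here means a more soluble compound, a lower number a less soluble compound.
Compound 2 `CCCN(CCC)CCNc1n[n+]([O-])c2ccccc2[n+]1[O-]` gives > 25000000 nM in this assay.

The value of compound 1 is a limit of the assay, (the limit of > 49000000 nM in this assay, at which 1 of the 2 values shown sits). The value of compound 2 is likewise a limit, (the limit of > 25000000 nM in this assay, at which 1 of the 2 values shown sits). Among the measured compounds shown here, the only measured step, a step that the two limits leave unreadable from compound 1 to compound 2, therefore stays unreadable, and compound 2 stands at a limit with no number beside it. Compound 3 `CCCN(CCC)CCNc1n[n+]([O-])c2ccc(Cl)cc2[n+]1[O-]` differs by chloro in place of hydrogen on an aromatic carbon. For the measured compounds named here, no measured step bears on this change, so no direction beyond the scatter can be read for it. Compound 3 is expected to remain readily soluble, estimated at 20000000 nM with a range from 4000000 nM to 60000000 nM. The expected step is an at least 1.2-fold lower number from compound 2 to compound 3 (0.09 log units; that floor lies within the scatter).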

Compound 3, solubility: 600000 nM
For compound 3 the middle estimate is 33-fold (1.52 log units) above the measured one; measured number below the stated range.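

Chloro in place of hydrogen on an aromatic carbon, meta to a fused ring and para to a fused ring, gives the first readable step of the series in this assay: an at least 41-fold lower number from compound 2 to compound 3 (1.61 log units; beyond the scatter). The read-out therefore moves beyond the scatter with a change on the aromatic part of the shared core. That size is only a floor, since compound 2 stands at a limit: the limit of > 25000000 nM in this assay, at which 1 of the 3 values shown sits.

Going by these compounds, whether fluoro or methoxy at this place would give a similar step remains open, as does the effect of chloro with piperidin-1-yl in place of dipropylamino. The step from compound 1 to compound 2 cannot be read.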